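Compound 3 and the sulfo step in a cytotoxicity test

This account rests on a few compounds, and the source may have more. Where it says the series, first, only, none or still open, it means among the compounds named here.

In an ADME assay on MDCK cells (Canis lupus familiaris) for cytotoxicity, with a stated time of 48 h (on this read-out lower numbers stand for higher toxicity in this test and higher numbers for lower toxicity in this test), three compounds sharing one core have been examined so far, and none of them has given a plain number. Compound 1 (`CCC(CC)O[C@@H]1C=C(B(O)O)C[C@H](NC(=N)N)[C@H]1NC(C)=O`) has the entry "not determined" (no result reported) in this test, so no result stands for it. Compound 2 (`CCC(CC)O[C@@H]1C=C([B-](F)(F)F)C[C@H](NC(=N)N)[C@H]1NC(C)=O`) likewise has the entry "not determined" (no result reported) in this test. Compound 3 (`CCC(CC)O[C@@H]1C=C([S+]([O-])O)C[C@H](NC(=N)N)[C@H]1NC(C)=O`) reads > 100000 nM in this test, and that is a limit of the assay, not a number. Going by the values given here, the record therefore offers only the limit of > 100000 nM in this assay, at which 1 of the 3 values shown sits, and no measured step between compounds.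

Compound 4 (`CCC(CC)O[C@@H]1C=C(S(=O)(=O)O)C[C@H](NC(=N)N)[C@H]1NC(C)=O`) is still to be measured. On a double-bonded ring carbon of a six-membered non-aromatic ring of carbon only, it carries a sulfo group in place of the group found in compound 3, a change counted as (a group of 4 heavy atoms (3 oxygen, 1 sulfur; no ring) in place of a group of 3 heavy atoms (2 oxygen, 1 sulfur; no ring), on a double-bonded ring carbon). No step beyond the usual scatter is expected for this change in this assay in either direction, and another limit is the likeliest report. This expectation rests on compound 3 alone, whose reading of > 100000 nM is a limit. The expected change is a number no higher from compound 3 to compound 4 (the limit leaves the size open) on this estimate. Compound 4 is estimated at 100000 nM with an expected range from 60000 nM to 150000 nM in this test.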

Compound 4, half-maximal cytotoxic concentration: > 100000 nM
Compound 4: a limit, no number; the forecaster's own chance of this, stated with the estimate: 90%; the middle value lies on the limit itself.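

In this assay compound 3 and compound 4 each stand at a limit and not at a number, so no step can be read between them: the limit of > 100000 nM in this assay, at which 2 of the 4 values shown sit. Left open is whether the sulfo group and the group it replaces differ at all on the shared core, and where either compound would give a plain number.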